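From a cyano to a diethylsulfamoyl group: cytotoxicity outlook

This account rests on a few compounds, and the source may have more. Where it says the series, first, only, none or still open, it means among the compounds named here.

Compound 1 `N#Cc1cccc(C(=O)N2CCCC(C(=O)Nc3ccc(Cl)cc3)C2)c1` and compound 2 `O=C(c1ccccc1)c1cccc(NC(=O)C2CCCN(C(=O)c3cc(C(F)(F)F)cc(C(F)(F)F)c3)C2)c1` share a core and have both been examined in an ADME assay on PC-3 cells (Homo sapiens) for cytotoxicity, read by WST assay, tested at 100 uM; a higher number here means more inhibition at the concentration tested (going by the name of the read-out), a lower number less inhibition. In this assay compound 1 gives 0%, and compound 2 gives 0%. The two readings are level with each other, and both sit at the bottom of the scale, so neither compound shows a measurable effect on the cells at the concentration tested. Compound 3 `CCN(CC)S(=O)(=O)c1cccc(C(=O)N2CCCC(C(=O)Nc3ccc(Cl)cc3)C2)c1` has not yet been measured. It differs from compound 1 in one place: diethylsulfamoyl in place of cyano on an aromatic carbon. Going by the values given here, with only two readings available, both at zero, nothing in the data points to a move in either direction for this kind of change. The step is expected to be a number 4 percentage points higher from compound 1 to compound 3 (within the scatter), that is, none beyond the scatter. Compound 3 is therefore expected to give about 4% in this assay, within a range of 0% to 22%.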

Compound 3, a percentage reported as inhibition, at one concentration (the size of the read-out at that concentration, not a potency): 0%
For compound 3 the middle estimate is 4 percentage points above the measured one, within the range that was stated.
By their numbers in this assay, from the lowest: compounds 1, 2 and 3 (each within the scatter of the next).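

In this assay diethylsulfamoyl can take the place of cyano on this aromatic carbon with no shift in the reading (no change at the digits printed from compound 1 to compound 3 (within the scatter)). Going by these compounds alone, this is the first change in one place in the set, and it shows that a group with more heavy atoms, and with sulfur and two oxygens that cyano lacks, still leaves the cells without a measurable effect at the concentration tested. No supporting measurement bears on why the reading stays the same.

Since both readings lie at the bottom of the scale, any difference that might exist between these two groups stays hidden here. As far as these compounds go, whether an amine or a carboxylic acid on this same aromatic carbon would also leave the reading at the bottom remains open.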